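The compounds below may be only part of what the source reports. "The series", "measured", "known", "first", "only" and "open" are said of these compounds alone.

Compound 2, `CNC(=O)c1cc(Oc2ccc3nc(Nc4ccc(C(F)(F)F)cc4)ncc3c2)ccn1`, sits at the lower limit of an ADME assay on Caco-2 cells (Homo sapiens) for permeability, in the apical to basolateral direction; on this read-out lower numbers stand for lower permeability and higher numbers for higher permeability: in this assay compound 2 gives < 1 10^-6 cm/s, which is a limit of the assay rather than a number. Compound 1, `CNC(=O)c1cc(Oc2ccc3nc(Nc4ccc(Br)cc4)ncc3c2)ccn1`, is in the same position: in this assay compound 1 gives < 1 10^-6 cm/s, again a limit. Among the compounds with values here, the only measured step, a step that the two limits leave unreadable from compound 1 to compound 2, therefore cannot be read in size, since both of its ends rest on (the limit of < 1 10^-6 cm/s in this assay, at which 2 of the 2 values shown sit). Compound 3, `CNC(=O)c1cc(Oc2ccc3nc(Nc4ccc(Oc5ccccc5)cc4)ncc3c2)ccn1`, differs from compound 2 by phenoxy in place of trifluoromethyl on an aromatic carbon. Within the data shown here, the one measured step touches this same position yet offers no size or direction, so nothing in the data points to a step beyond the scatter; with both measured compounds at the limit, compound 3 is expected to stay near that limit, and the step that the limit leaves unreadable from compound 2 to compound 3 is expected to lie within the scatter. In this assay compound 3 is estimated at 0.8 10^-6 cm/s, with a range from 0.3 10^-6 cm/s to 3 10^-6 cm/s.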

Compound 3, apparent permeability: < 1 10^-6 cm/s
Compound 3: a limit, no number (the forecaster's own chance of this, stated with the estimate: 60%); the middle value lies beyond the limit too.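

Compound 3 gives a limit rather than a number, as do compound 1 and compound 2, and no step among these three compounds can be read in size: the limit of < 1 10^-6 cm/s in this assay, at which 3 of the 3 values shown sit. From the compounds shown here alone, whether bromo, trifluoromethyl and phenoxy differ at all in this assay stays open.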